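A pyridin-4-yl swap at the assay limit

A few compounds are considered here, and "the series" means these few. Any claim that something is new, unique, unknown or untested is made for them only; others in the source may bear on it.

compound 1 `O=C(Nc1cccc(F)c1)c1cc(=O)[nH]c2cc(-c3ccccc3)ccc12`: > 20000 nM
compound 2 `CC(=O)c1ccc(-c2ccc3c(C(=O)Nc4cccc(F)c4)cc(=O)[nH]c3c2)cc1`: > 20000 nM
compound 3 `COc1ccc(-c2ccc3c(C(=O)Nc4cccc(F)c4)cc(=O)[nH]c3c2)cc1`: > 20000 nM

All three entries are limits, not numbers. In a functional assay on KYSE-70 cells for antiproliferative activity against KYSE-70 cell line (Homo sapiens), read by MTT assay, with a stated time of 72 h (on this read-out higher numbers stand for weaker inhibition and lower numbers for stronger inhibition), compound 3 gives > 20000 nM, and this is a limit. Compound 3 therefore shares the limit of > 20000 nM in this assay, at which 3 of the 3 values shown sit, with the other two, and no order among the three can be read.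

The next compound to be tested is compound 4 `O=C(Nc1cccc(F)c1)c1cc(=O)[nH]c2cc(-c3ccncc3)ccc12`. It keeps the shared core and the amide and changes one group: pyridin-4-yl in place of 4-methoxyphenyl on an aromatic carbon. The new group, like the old one, sits on an aromatic carbon of the core.

Within the data shown here, three measured steps bear on this change, as each of them alters the aromatic group at this same place: a step that the two limits leave unreadable from compound 1 to compound 2, a step that the two limits leave unreadable from compound 1 to compound 3 and a step that the two limits leave unreadable from compound 2 to compound 3. None of them has a readable size. They show only that the hydrogen, acetyl and methoxy versions all ended at the limit. With no measured number in this set to suggest a gain, no readable change in this assay is expected, in either direction. The estimated step is a number no higher from compound 3 to compound 4 (the limit leaves the size open). For compound 4 the expected value is 20000 nM, with an estimated range of 8000 nM to 40000 nM, and a report of only a limit is the likeliest outcome.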

Compound 4, half-maximal inhibitory concentration: > 20000 nM
Compound 4: only a limit was reported (the forecaster's own chance of this, stated with the estimate: 80%); the middle value sits exactly at the limit.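

No step from compound 1, compound 2 or compound 3 to compound 4 can be read in this assay, as compound 4 also gives only a limit and all four compounds share it: the limit of > 20000 nM in this assay, at which 4 of the 4 values shown sit.

The compounds shown leave open how the four rank against one another, and whether any group at this place on the shared core can give a measurable value.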